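From 2-nitrophenyl to 4-nitrophenyl: what happens to potency?

The source may report more compounds than this note shows. Statements on the series, on what has been measured and on what is new or still open speak of the compounds shown alone.

Two compounds have been measured in a functional assay on NSCLC cells (Homo sapiens) for antiproliferative activity (on this read-out lower numbers stand for stronger inhibition and higher numbers for weaker inhibition), so far
compound 1 `N#CN/C(=N\CCCCCCOc1ccccc1)Nc1cccnc1` gives 52 nM
compound 2 `N#CN/C(=N\CCCCCCOc1ccccc1[N+](=O)[O-])Nc1ccncc1` gives 0.6 nM

Compound 2 holds the lower number of the two, and the gap to compound 1 lies beyond the scatter, so compound 2 is the stronger inhibitor here. The next compound, compound 3 `N#CN/C(=N\CCCCCCOc1ccc([N+](=O)[O-])cc1)Nc1ccncc1`, has the same atoms as compound 2, joined differently. Within the data shown here, the change is 4-nitrophenyl in place of 2-nitrophenyl on an oxygen on a saturated carbon, and no measured pair shows what such a change does. A modest weakening towards a higher number is expected, with an estimated 3.3-fold higher number from compound 2 to compound 3 (0.52 log units; beyond the scatter) in this assay. Compound 3 is estimated at 2 nM with an expected range from 0.3 nM to 15 nM.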

Compound 3, half-maximal inhibitory concentration: 52 nM
The estimate for compound 3 lay 26-fold (1.41 log units) below the measured number; measured number outside the range, above it.
By their numbers in this assay, from the lowest: compound 2; then compounds 1 and 3 (each within the scatter of the next).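

Replacing 2-nitrophenyl with 4-nitrophenyl on an oxygen on a saturated carbon, in this assay, gives an 87-fold higher number from compound 2 to compound 3 (1.94 log units; beyond the scatter), a large loss of potency. The two compounds have the same atoms, so how those atoms are joined at this group alone separates strong from much weaker inhibition here. No measurement available explains why this change matters so much.

As far as these compounds go, it remains open whether 3-nitrophenyl, or a phenyl ring carrying an amine or a carboxylic acid in place of the nitro group, would keep the potency of compound 2. From the compounds shown here alone, it is also open whether a longer chain would alter the size of this step.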